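Substituent changes on the aryl ring of a shared core

The source may hold more compounds than are shown below. What is called first, only, known or untested is meant among the compounds shown, and "the series" means these compounds.

Measured so far:
compound 1, `c1ccc(-c2nnc(Nc3ncccn3)o2)cc1`, 51.4%
compound 2, `Fc1ccc(-c2nnc(Nc3ncccn3)o2)cc1`, 41.9%
compound 3, `Clc1ccc(-c2nnc(Nc3ncccn3)o2)cc1`, 46.2%

All three were tested in a functional assay, with a stated time of 30 min, tested at 20 uM; a lower number here means less inhibition, a higher number more inhibition at the concentration tested (going by the name of the read-out). Compound 3 stands second highest of the three numbers, with compound 2 nearest and compound 1 furthest, and both of those gaps are within the scatter. The steps already seen all touch the same aromatic carbon: a number 9.5 percentage points lower from compound 1 to compound 2 (within the scatter), a number 5.2 percentage points lower from compound 1 to compound 3 (within the scatter) and a number 4.3 percentage points higher from compound 2 to compound 3 (within the scatter). None of them reaches beyond the scatter, so the three compounds cannot be ordered.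

Compound 4, `O=[N+]([O-])c1ccc(-c2nnc(Nc3ncccn3)o2)cc1`, is not yet measured. It differs from compound 3 in one place: nitro in place of chloro on an aromatic carbon. For the measured compounds named here, the steps that bear on this change are the ones at that position, from hydrogen to fluoro, from hydrogen to chloro and from fluoro to chloro, and each of them was small. Going by the values given here, no step beyond the scatter is therefore expected for compound 4 in this assay, in either direction; the nitro group has no precedent here, so the range is kept wide. The expected step is a number 0.8 percentage points higher from compound 3 to compound 4 (within the scatter). Compound 4 is estimated at 47%, with a range from 30% to 64%.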

Compound 4, a percentage reported as inhibition, at one concentration (the size of the read-out at that concentration, not a potency): < 20%
Compound 4: no number, only a limit (the forecaster's own chance of this, stated with the estimate: 2%); middle value at least 27 percentage points from the limit.
By their numbers in this assay, from the lowest: compounds 2, 3 and 1 (each within the scatter of the next). At a limit, below all of these: compound 4.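

In this assay, for the compounds shown here, nitro is the first change at this aromatic carbon to give steps beyond the scatter: a number at least 26.2 percentage points lower from compound 3 to compound 4 (beyond the scatter), a number at least 21.9 percentage points lower from compound 2 to compound 4 (beyond the scatter) and a number at least 31.4 percentage points lower from compound 1 to compound 4 (beyond the scatter). For compound 4, the reading of < 20% is a limit of the assay and not a number: the limit of < 20% in this assay, at which 1 of the 4 values shown sits. Hydrogen, fluoro and chloro could not be ordered at this position, so the earlier compounds gave no sign that it could separate substituents, whereas compound 4 now stands apart from all three.

With nitro as the only group of its kind here, the compounds shown cannot tell whether this drop goes with the 3 heavy atoms and 2 hydrogen-bond acceptors that enter in place of chloro or with something else about the group, and an amine, a nitrile or a carboxylic acid on the same carbon would help to separate these. They also leave open whether nitro would give a similar step on another carbon of the aryl ring, or on a core other than the shared one.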